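From Methyl to Butyl on the Aromatic Nitrogen

The source may report more compounds than this note shows. Statements on the series, on what has been measured and on what is new or still open speak of the compounds shown alone.

Measured so far:
compound 1 `Nc1nc2ccc(OCC(F)(F)C(F)(F)F)cc2s1` — 7.5 mg/kg
compound 2 `Cn1c(=N)sc2cc(OC(F)(F)F)ccc21` — 5 mg/kg

Among the compounds with values here, in a functional assay on the whole organism with Rattus norvegicus as the target (on this read-out lower numbers stand for an effect already at smaller amounts and higher numbers for an effect only at larger amounts of compound), compound 2 gives 5 mg/kg, the lower of the two numbers known so far. Compound 1 gives 7.5 mg/kg in this assay, and the gap between the two lies within the scatter, so the pair shows no real difference. Within the data shown here, no step between measured compounds that differ in a single place is available, and the two structures differ in several places at once.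

Compound 3 `CCCCn1c(=N)sc2cc(OC(F)(F)F)ccc21` departs from compound 2 by propyl in place of hydrogen on a saturated chain carbon bound to an aromatic nitrogen. Among the measured compounds shown here, nothing among the measured compounds tracks such a change, so the expected step in this assay is modest, at most a slight shift toward higher doses, and possibly none beyond the scatter. Compound 3 is therefore estimated at 7 mg/kg, within 2 mg/kg to 25 mg/kg. That estimate means an expected step of a 1.4-fold higher number from compound 2 to compound 3 (0.15 log units; within the scatter).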

Compound 3, dose for half-maximal effect: 10 mg/kg
Beside the measured number, compound 3's estimate is 1.4-fold (0.15 log units) below it, within the range that was stated.
By their numbers in this assay, from the lowest: compounds 2, 1 and 3 (each within the scatter of the next).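

Within the data shown here, the pair gives the first comparison in which only one place differs: in this assay there is a 2.0-fold higher number from compound 2 to compound 3 (0.30 log units; within the scatter) with propyl in place of hydrogen on a saturated chain carbon bound to an aromatic nitrogen. Read as methyl to butyl, this means that the position takes the longer chain with no difference that stands beyond the scatter, so the whole-animal read-out does not separate the two chain lengths. Nothing measured here speaks to what lies behind this result.

As far as these compounds go, whether a still longer chain such as octyl would produce a step beyond the scatter remains open. So does the outcome of ending the chain on this nitrogen in an amine or a carboxylic acid, or of replacing it with benzyl.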